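A Pyridine Swap on the Biaryl Tail

The source may report more compounds than this note shows. Statements on the series, on what has been measured and on what is new or still open speak of the compounds shown alone.

Compound 1 `CC(Nc1c(C#N)c(-c2ccc(Br)cc2)nc2cnccc12)C(N)=O` gives 2.1.
Compound 2 `CCOc1ccccc1-c1ccc(-c2nc3cnccc3c(NC(C(N)=O)C3CC3)c2C#N)cc1` gives 3.
Compound 3 `CC[C@@H](Nc1c(C#N)c(-c2ccc(-c3cccc(OC)c3)cc2)nc2cnccc12)C(N)=O` gives 2.7.

In a physicochemical assay for lipophilicity, read by HPLC, at pH 7.5 (on this read-out lower numbers stand for lower lipophilicity and higher numbers for higher lipophilicity), compound 3 stands second highest of the three measured numbers. Compound 2 lies within the scatter of compound 3, so the two cannot be ordered, whereas compound 1 sits lower than compound 3 by a gap beyond the scatter. Compound 4 `CC[C@@H](Nc1c(C#N)c(-c2ccc(-c3ccncc3C)cc2)nc2cnccc12)C(N)=O` has not yet been measured. It differs from compound 3 in one place: 3-methylpyridin-4-yl in place of 3-methoxyphenyl on an aromatic carbon. Within the data shown here, no step between measured compounds describes such a change, so the expectation rests on the change itself; a downward step beyond the scatter is expected, of about a number 0.90 log units lower from compound 3 to compound 4 (beyond the scatter). Compound 4 is therefore estimated at 1.8, with a range from 1.2 to 2.4.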

Compound 4, distribution coefficient: 2
Compound 4: middle estimate off by 0.20 log units, on the low side; low and high end bracket the measured number.
By their numbers in this assay, from the lowest: compounds 4 and 1 (each within the scatter of the next); then compounds 3 and 2 (each within the scatter of the next).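

In this assay, putting 3-methylpyridin-4-yl in place of 3-methoxyphenyl on this aromatic carbon, para to a large group, gives a number 0.70 log units lower from compound 3 to compound 4 (beyond the scatter) and so shows that the read-out responds to the group held here. The change swaps a ring of carbon only for a ring with 1 hetero atom, with the hydrogen-bond donor and acceptor counts unchanged. No measurement shown accounts for the step.

Among these compounds, the single swap leaves open how much of the step belongs to the ring nitrogen and how much to the methyl. From the compounds shown here alone, how a plain pyridin-4-yl or a carboxylic acid on this carbon would read also remains open.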